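Side-chain swap from compound 3 to compound 4

This account rests on a few compounds, and the source may have more. Where it says the series, first, only, none or still open, it means among the compounds named here.

In an ADME assay on microsomes from liver (Homo sapiens) for metabolic stability, read by LC-MS, tested at 1 uM (a lower number here means slower removal, a higher number faster removal of the compound), compound 1 `NC(=O)C1CCN(Cc2ccc([C@H]3CC[C@]4(CC3)OOC3(O4)C4CC5CC(C4)CC3C5)cc2)CC1` gives 10 mL.min-1.g-1, compound 2 `OC1(COc2ccc([C@H]3CC[C@]4(CC3)OOC3(O4)C4CC5CC(C4)CC3C5)cc2)CCNCC1` gives 16 mL.min-1.g-1 and compound 3 `CC(C)(O)CN1CCC(Oc2ccc([C@H]3CC[C@]4(CC3)OOC3(O4)C4CC5CC(C4)CC3C5)cc2)CC1` gives 18 mL.min-1.g-1. Compound 3 therefore stands within the scatter of both other compounds.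

Compound 4 `c1cc([C@H]2CC[C@]3(CC2)OOC2(O3)C3CC4CC(C3)CC2C4)ccc1OCCC1CCNCC1` carries 2-(piperidin-4-yl)ethyl in place of 1-(2-hydroxy-2-methylpropyl)piperidin-4-yl on an oxygen on an aromatic ring.

The closest measured change is a 1.1-fold higher number from compound 2 to compound 3 (0.05 log units; within the scatter), made on the same oxygen. The changes on the aromatic carbon are a 1.6-fold higher number from compound 1 to compound 2 (0.20 log units; within the scatter) and a 1.8-fold higher number from compound 1 to compound 3 (0.26 log units; within the scatter). All three stay within the scatter, so none of these side-chain changes gives a measurable shift among these compounds. Within the data shown here, no measured compound carries the 2-(piperidin-4-yl)ethyl group, so the data offer no direct reading for it, and the uncertainty stays wide.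

No step beyond the scatter is expected in this assay, and the estimated step is a 1.1-fold higher number from compound 3 to compound 4 (0.05 log units; within the scatter). For compound 4 the estimated value is 20 mL.min-1.g-1, with an expected range from 9 mL.min-1.g-1 to 45 mL.min-1.g-1.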

Compound 4, intrinsic clearance in microsomes: < 7 mL.min-1.g-1
Compound 4 was reported as a limit (the forecaster's own chance of this, stated with the estimate: 3%); middle value at least 2.8-fold (0.45 log units) from the limit.
By their numbers in this assay, from the lowest: compounds 1, 2 and 3 (each within the scatter of the next). At a limit, below all of these: compound 4.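

In this assay compound 4 is reported only as a limit, the only one in the set: the limit of < 7 mL.min-1.g-1 in this assay, at which 1 of the 4 values shown sits. Among these compounds, on the oxygen on an aromatic ring, 2-(piperidin-4-yl)ethyl gives the first steps beyond the scatter, an at least 2.5-fold lower number from compound 3 to compound 4 (0.41 log units; beyond the scatter) and an at least 2.2-fold lower number from compound 2 to compound 4 (0.35 log units; beyond the scatter), whereas all earlier side-chain changes stayed within it, so this position is not insensitive to the side chain. The remaining step, an at least 1.4-fold lower number from compound 1 to compound 4 (0.15 log units; that floor lies within the scatter), leaves the relation to the carbamoyl-bearing side chain unresolved.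

The step from the 4-hydroxypiperidin-4-yl side chain combines the loss of the hydroxyl with a change in the chain, so the two cannot be told apart. A hydroxyl on the 2-(piperidin-4-yl)ethyl group, or a longer 3-(piperidin-4-yl)propyl chain on the same oxygen, would separate these contributions.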